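The compounds below may be only part of what the source reports. "The series", "measured", "known", "first", "only" and "open" are said of these compounds alone.

In an ADME assay on microsomes from liver (Mus musculus) for metabolic stability, read by LC-MS, using NADPH, with stated times of 10 min and 30 min (a lower number here means slower removal, a higher number faster removal of the compound), compound 2 `O=C1c2ccc(Cl)cc2CN1c1cccnc1` gives 76.5 mL/min/kg, the highest of the two true numbers at hand. Compound 1 `O=C1c2cc(F)c(Cl)cc2CCN1c1cccnc1` gives 30.9 mL/min/kg, a lower number by a gap that lies beyond the scatter. The third measured compound, compound 3 `CC(=O)N[C@@H]1CCCc2c1cncc2N1C(=O)c2ccc(Cl)cc2[C@@H]1C`, is reported only as a limit, < 20.2 mL/min/kg, and not as a number.

The next compound to be tested is compound 4 `CC1c2cc(Cl)ccc2C(=O)N1c1cccnc1`. It is compound 2 with one change, methyl in place of hydrogen on a saturated ring carbon. Among the measured compounds shown here, compound 3 also carries a methyl on a saturated ring carbon, but it differs from compound 2 in other places too, and no measured pair isolates this change. The only support for a direction is therefore weak: the limit of compound 3, < 20.2 mL/min/kg, hints that a methyl at this kind of carbon need not bring a high clearance.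

A modest fall in this assay is expected, probably no larger than the scatter, and the expected step is a 1.4-fold lower number from compound 2 to compound 4 (0.14 log units; within the scatter). For compound 4 the estimated clearance is 55 mL/min/kg, with an expected range from 28 mL/min/kg to 100 mL/min/kg.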

Compound 4, clearance: 66.5 mL/min/kg
For compound 4 the middle estimate is 1.2-fold (0.08 log units) below the measured one; measured number inside the range.
By their numbers in this assay, from the lowest: compound 1; then compounds 4 and 2 (each within the scatter of the next). At a limit, below all of these: compound 3.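

In this assay, among the compounds shown here, this is the first measured pair that isolates methyl in place of hydrogen on a saturated ring carbon, next to the ring nitrogen, and it gives a 1.2-fold lower number from compound 2 to compound 4 (0.06 log units; within the scatter). The step lies within the scatter, so at this position, on this core, the single methyl leaves the clearance without a change that can be told from repeat measurement. Compound 3 also carries a methyl on a saturated ring carbon, but it differs from compound 2 in other places too and stands only as a limit, not as a number, so it cannot be read against this step: the limit of < 20.2 mL/min/kg in this assay, at which 1 of the 4 values shown sits.

Going by these compounds, it remains open whether a larger or different group on this same carbon, such as an ethyl chain, a hydroxyl or an amine, would move the clearance beyond the scatter. Also open is whether the two mirror-image forms of compound 4 behave alike, since the compounds shown include no pair that separates them.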